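Chloro to aminomethyl: expected cytotoxicity of compound 3

The source may hold more compounds than are shown below. What is called first, only, known or untested is meant among the compounds shown, and "the series" means these compounds.

Measured so far:
compound 1, `COc1ccc(S(=O)(=O)c2cn(-c3ccc4c(c3)B(O)OC4)c3ccccc23)cc1`: > 10 ug/mL
compound 2, `O=C(c1ccc(Cl)cc1)c1ccn(-c2ccc3c(c2)B(O)OC3)c1`: > 10 ug/mL

Both compounds were tested in an ADME assay on L929 cells (Mus musculus) for cytotoxicity, read by resazurin assay, with a stated time of 72 h; on this read-out higher numbers stand for weaker inhibition and lower numbers for stronger inhibition. Compound 1 gives > 10 ug/mL, which is a limit of the assay rather than a number. Compound 2 gives > 10 ug/mL, again a limit and not a measured number. On the numbers shown, compound 2 therefore stands at the limit of > 10 ug/mL in this assay, at which 2 of the 2 values shown sit.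

Compound 3, `NCc1ccc(C(=O)c2ccn(-c3ccc4c(c3)B(O)OC4)c2)cc1`, has not yet been measured. It differs from compound 2 in a single place: aminomethyl in place of chloro on an aromatic carbon. Within the data shown here, no step between two measured compounds is available, so the size of this kind of change cannot be read off a measured pair here. With every value shown sitting at the limit, the expected step in this assay is a step that the limit leaves unreadable from compound 2 to compound 3, that is, none beyond the usual scatter, and the result for compound 3 is expected most likely to come back again as a limit. Compound 3 is thus estimated at 15 ug/mL, with a range of 7 ug/mL to 40 ug/mL.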

Compound 3, half-maximal inhibitory concentration: > 10 ug/mL
Compound 3 was reported as a limit; the forecaster's own chance of this, stated with the estimate: 75%; the middle value lies beyond the limit too.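

No step can be read from compound 2 to compound 3, since both results are limits of the assay rather than numbers: the limit of > 10 ug/mL in this assay, at which 3 of the 3 values shown sit. What stays open is how strongly any of these compounds acts in this assay and whether aminomethyl in place of chloro changes that at all.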